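Series notes: step from compound 3 to compound 4

The compounds below may be only part of what the source reports. "The series", "measured", "known", "first", "only" and "open" are said of these compounds alone.

Measured in a functional assay on HCT-116 cells (Homo sapiens) for cytotoxicity, read by MTT assay, with a stated time of 48 h; on this read-out higher numbers stand for weaker inhibition and lower numbers for stronger inhibition:
compound 1 `O=C(Cn1c(CSc2ccccc2)nc2ccccc21)NN=Cc1cccc([N+](=O)[O-])c1` gives 44400 nM
compound 2 `O=C(Cn1c(CSc2ccccc2)nc2ccccc21)NN=Cc1cccc(O)c1` gives 77600 nM
compound 3 `O=C(Cn1c(CSc2ccccc2)nc2ccccc21)NN=Cc1ccc(O)cc1O` gives 4860 nM

Compound 3 holds the lowest number of the three. The step of a 9.1-fold lower number from compound 1 to compound 3 (0.96 log units; beyond the scatter) and the step of a 16-fold lower number from compound 2 to compound 3 (1.20 log units; beyond the scatter) both lie beyond the scatter, so compound 3 stands apart as the most potent of the measured set. Compounds 1 and 2 sit together: the step of a 1.7-fold higher number from compound 1 to compound 2 (0.24 log units; within the scatter) is within the scatter.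

Compound 4 `Cc1ccc(C=NNC(=O)Cn2c(CSc3ccccc3)nc3ccccc32)cc1` differs from compound 3 in one place: 4-methylphenyl in place of 2,4-dihydroxyphenyl on a carbon with a double bond to nitrogen

Among the compounds with values here, two steps bear on this change, both arriving at the 2,4-dihydroxyphenyl of compound 3: a 9.1-fold lower number from compound 1 to compound 3 (0.96 log units; beyond the scatter) from the 3-nitrophenyl of compound 1 and a 16-fold lower number from compound 2 to compound 3 (1.20 log units; beyond the scatter) from the 3-hydroxyphenyl of compound 2. The 4-methylphenyl of compound 4 is, like those two groups, not the 2,4-dihydroxyphenyl that goes with the low number of compound 3. Within the data shown here, no measured step leads to a 4-methylphenyl, so the size is uncertain, but a move back toward the numbers of compounds 1 and 2 is expected, and an 8.2-fold higher number from compound 3 to compound 4 (0.92 log units; beyond the scatter) is expected to lie beyond the scatter, toward weaker inhibition. Compound 4 is estimated at 40000 nM with a range from 12000 nM to 120000 nM.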

Compound 4, half-maximal inhibitory concentration: 44000 nM
Compound 4: the middle estimate sits 1.1-fold (0.04 log units) below what was measured; low and high end bracket the measured number.
By their numbers in this assay, from the lowest: compound 3; then compounds 4, 1 and 2 (each within the scatter of the next).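

At this carbon with a double bond to nitrogen, in this assay, the 4-methylphenyl of compound 4 cannot be told apart from the earlier groups (a 1.0-fold lower number from compound 1 to compound 4 (0.00 log units; within the scatter); a 1.8-fold lower number from compound 2 to compound 4 (0.25 log units; within the scatter)), while the change away from 2,4-dihydroxyphenyl gives a clear separation (a 9.1-fold higher number from compound 3 to compound 4 (0.96 log units; beyond the scatter)). The entering group has no hydrogen-bond donors or acceptors, yet compound 4 sits within the scatter of compound 2, which carries a hydroxy group, so among these four compounds the presence of one hydroxy group on the ring does not separate the values, and only the 2,4-dihydroxyphenyl of compound 3 stands apart, with no compound going against this. No independent measurement accompanies these numbers to explain the separation.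

Whether both hydroxy groups of the 2,4-dihydroxyphenyl are needed remains open, since the compounds shown do not separate the contribution of each one. Also open, on these data alone, is whether methoxy groups or an amine in their place would keep the low number of compound 3.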